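From Phenyl to 4-Chloro-3-fluorophenyl: An Expected Limit

The compounds below may be only part of what the source reports. "The series", "measured", "known", "first", "only" and "open" are said of these compounds alone.

Compound 1 `Cn1ccc2c(Oc3ccc(NC(=O)c4nn(-c5ccc(Cl)cc5)ccc4=O)cc3)ccnc21`: > 60000 nM
Compound 2 `COc1ccc(-n2ccc(=O)c(C(=O)Nc3ccc(Oc4ccnc5c4ccn5C)cc3)n2)cc1`: > 60000 nM
Compound 3 `Cn1ccc2c(Oc3ccc(NC(=O)c4nn(-c5ccccc5)ccc4=O)cc3)ccnc21`: 56200 nM

Three compounds share one core and differ only in the group on the aromatic nitrogen. Within the data shown here, in a functional assay on HepG2 cells (Homo sapiens) for cytotoxicity, read by MTT assay, with a stated time of 72 h (on this read-out higher numbers stand for weaker inhibition and lower numbers for stronger inhibition), compound 3 gives 56200 nM, the only genuine number among the three. Compound 1 gives > 60000 nM, which is a limit of the assay and not a number. Compound 2 likewise gives > 60000 nM, again a limit. The step of an at least 1.0-fold lower number from compound 1 to compound 3 (0.02 log units; that floor lies within the scatter) and the step of an at least 1.0-fold lower number from compound 2 to compound 3 (0.02 log units; that floor lies within the scatter) therefore rest on floors that lie within the scatter, and the step that the two limits leave unreadable from compound 1 to compound 2 cannot be read at all (the limit of > 60000 nM in this assay, at which 2 of the 3 values shown sit).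

Compound 4 `Cn1ccc2c(Oc3ccc(NC(=O)c4nn(-c5ccc(Cl)c(F)c5)ccc4=O)cc3)ccnc21` is not yet measured. It carries 4-chloro-3-fluorophenyl in place of phenyl on an aromatic nitrogen. Among the measured compounds shown here, the one step that bears on it is an at least 1.0-fold lower number from compound 1 to compound 3 (0.02 log units; that floor lies within the scatter), since compound 4 brings back the chloro of compound 1 and adds a fluorine on the same ring; that step reached only its floor. The expected step of a 1.1-fold higher number from compound 3 to compound 4 (0.03 log units; within the scatter) is thus none beyond the scatter, with the number more likely to fall at the limit again. Compound 4 is expected to give 60000 nM, within 35000 nM to 120000 nM.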

Compound 4, half-maximal inhibitory concentration: > 60000 nM
Compound 4 gave a limit, no number; the forecaster's own chance of this, stated with the estimate: 65%; the middle value sits exactly at the limit.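

In this assay compound 4 gives > 60000 nM, which is a limit of the assay and not a number. Among these compounds, the one comparison open to it is an at least 1.0-fold higher number from compound 3 to compound 4 (0.02 log units; that floor lies within the scatter), so 4-chloro-3-fluorophenyl in place of phenyl on the aromatic nitrogen shows no separation from phenyl that can be sized, and the steps to compound 4 from compound 1 and compound 2 cannot be read, since both ends of each are limits. The earlier compounds showed this for a single group on the phenyl ring, and compound 4 extends it to a ring with two: among the four compounds, every substituted phenyl at this position ends at the limit and only compound 3, with plain phenyl, goes against that by giving a number: the limit of > 60000 nM in this assay, at which 3 of the 4 values shown sit.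

On these data alone, what stays open is whether any other group on this nitrogen would give a number clearly under the limit, for instance a pyridyl ring, a methyl group, or a phenyl ring carrying an amine or a carboxylic acid. As far as these compounds go, how compound 1, compound 2 and compound 4 rank against one another also stays open, as a limit offers no number to compare.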